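Cyclohexyl gives way to 4-chlorophenyl in compound 3

This account rests on a few compounds, and the source may have more. Where it says the series, first, only, none or still open, it means among the compounds named here.

- Compound 1 `COc1cc(NC(C)CCCNC(=O)NNC(=O)/C=C/c2ccccc2)c2ncccc2c1` gives 13900 nM in an ADME assay on L6 cells (Rattus norvegicus) for cytotoxicity, read by resazurin assay, with a stated time of 70 h; a lower number here means a stronger inhibitor, a higher number a weaker inhibitor
- Compound 2 `COc1cc(NC(C)CCCNC(=O)NNC(=O)NC2CCCCC2)c2ncccc2c1` gives "not determined" (no result reported) in this assay

Going by the values given here, compound 2 thus has no place on the scale, and the one number available belongs to compound 1. Compound 3 `COc1cc(NC(C)CCCNC(=O)NNC(=O)Nc2ccc(Cl)cc2)c2ncccc2c1` keeps the shared core of compound 2 and differs from it in a single group: 4-chlorophenyl in place of cyclohexyl on an amide-type nitrogen. With no measured value for compound 2, this change cannot be sized from its starting point. The nearest guide is compound 1 (13900 nM), so no step beyond the usual scatter from that value is expected in this assay, and neither direction is favoured. The estimated value for compound 3 is 15000 nM, with an expected range of 5000 nM to 45000 nM as the likely span of the measurement.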

Compound 3, half-maximal inhibitory concentration: 91900 nM
The estimate for compound 3 lay 6.1-fold (0.79 log units) below the measured number, outside the stated range (above it).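

Placing (4-chlorophenyl)amino instead of 2-phenylethenyl on a carbonyl carbon gives a 6.6-fold higher number from compound 1 to compound 3 (0.82 log units; beyond the scatter) in this assay, the first readable step in this series and one that lies beyond the scatter. It shows that this end of the molecule can change the read-out with the shared core kept intact, and that this change moves the number towards the weaker end of the scale. Compound 2 has no number, so the step from cyclohexyl to 4-chlorophenyl cannot be read, and nothing shown accounts for the size of the step from the 2-phenylethenyl compound.

The compounds shown leave open whether the chlorine itself matters or whether a plain phenyl ring would give a similar number. They also leave open how a 4-methoxyphenyl or 4-aminophenyl group would read at this position.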